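The source may hold more compounds than are shown below. What is called first, only, known or untested is meant among the compounds shown, and "the series" means these compounds.

Measured so far in a functional assay on HepG2 cells (Homo sapiens) for cytotoxicity, read by MTT assay, with a stated time of 48 h; on this read-out lower numbers stand for stronger inhibition and higher numbers for weaker inhibition:
- compound 1 `O=C1/C(=C\c2ccc(O)c(O)c2)S/C(=N/c2ccccc2)N1Cc1ccncc1`: 16200 nM
- compound 2 `O=C1/C(=C\c2ccccn2)S/C(=N/c2ccccc2)N1Cc1ccncc1`: 31000 nM

Not yet measured:
- compound 3 `Cc1ccc(/C=C2/S/C(=N/c3ccccc3)N(Cc3ccncc3)C2=O)s1`

Compound 2 has the higher of the two numbers, but its gap to compound 1 lies within the usual scatter, so neither compound can be called the stronger. Compound 3 keeps the shared core and carries 5-methylthiophen-2-yl in place of pyridin-2-yl on a double-bonded chain carbon bound to a double-bonded ring carbon.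

Among the compounds with values here, only one measured step bears on this change, because it was made at the same place: a 1.9-fold higher number from compound 1 to compound 2 (0.28 log units; within the scatter). In that step, pyridin-2-yl replaced 3,4-dihydroxyphenyl, and the result stayed within the scatter. Within the data shown here, no compound with a thiophene group has been measured yet, so this single step is thin evidence. It gives no reason to expect a real shift in this assay, in either direction. The expected change is a 1.3-fold lower number from compound 2 to compound 3 (0.13 log units; within the scatter), which would not stand out from the scatter. For compound 3 the estimate is 23000 nM, with an expected range from 10000 nM to 55000 nM.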

Compound 3, half-maximal inhibitory concentration: 23100 nM
For compound 3 the middle estimate is 1.0-fold (0.00 log units) below the measured one; the measured number falls inside the stated range.
By their numbers in this assay, from the lowest: compounds 1, 3 and 2 (each within the scatter of the next).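

In this assay, putting 5-methylthiophen-2-yl in place of pyridin-2-yl on a double-bonded chain carbon bound to a double-bonded ring carbon gives a 1.3-fold lower number from compound 2 to compound 3 (0.13 log units; within the scatter) and putting the same group in place of 3,4-dihydroxyphenyl gives a 1.4-fold higher number from compound 1 to compound 3 (0.15 log units; within the scatter). Within the data shown here, the earlier pair compared only two six-membered aromatic rings, whereas this place now also carries a five-membered aromatic ring with sulfur as its hetero atom, and all three compounds still cannot be told apart in this read-out. No measurement of any property of these groups is available to account for this result.

All three groups shown at this place are aromatic rings, so it remains open what an amine, a carboxylic acid or a longer chain would do there, and whether any group at this place can shift the number beyond the scatter. The rest of the shared core is identical in compounds 1, 2 and 3, which leaves open how strongly changes elsewhere on it would affect the number.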